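Removing the Nitro Group: From Compound 2 to Compound 3

The source may hold more compounds than are shown below. What is called first, only, known or untested is meant among the compounds shown, and "the series" means these compounds.

Measured compounds:
- compound 1 `N/N=C/c1cc2ccccc2[nH]c1=O`; in a functional assay, read by spectrophotometry, with a stated time of 3 min (on this read-out lower numbers stand for stronger inhibition and higher numbers for weaker inhibition), compound 1 gives 20600 nM
- compound 2 `O=c1[nH]c2ccccc2cc1/C=N/Nc1ccc([N+](=O)[O-])cc1`; in this assay compound 2 gives 11400 nM

Of the two measured compounds, compound 2 stands at the lower number in this assay, though its distance to compound 1 lies within the usual scatter, so the two cannot be told apart. Compound 3 `O=c1[nH]c2ccccc2cc1/C=N/Nc1ccccc1` differs from compound 2 by hydrogen in place of nitro on an aromatic carbon. Among the measured compounds shown here, no measured pair shows the effect of this change, so no size of step can be read from the data; a step no larger than the scatter in this assay is expected, if anything toward a higher number. Compound 3 is therefore estimated at 16000 nM, with a range from 5000 nM to 50000 nM. That expectation means a step of a 1.4-fold higher number from compound 2 to compound 3 (0.15 log units; within the scatter).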

Compound 3, half-maximal inhibitory concentration: 11800 nM
Estimate against measurement, compound 3: 1.4-fold (0.13 log units) above, and the stated range covers the measured number.
By their numbers in this assay, from the lowest: compounds 2, 3 and 1 (each within the scatter of the next).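

In this assay, hydrogen in place of nitro on an aromatic carbon, para to a large group, gives a 1.0-fold higher number from compound 2 to compound 3 (0.01 log units; within the scatter), so nitro and hydrogen cannot be told apart at this place. Phenyl in place of hydrogen on the amine nitrogen gives a 1.7-fold lower number from compound 1 to compound 3 (0.24 log units; within the scatter), so adding the unsubstituted ring also leaves a difference that cannot be told from the scatter. Nothing available accounts for these results.

On these data alone, whether an amine or a carboxylic acid at this place would give a step beyond the scatter remains open. So does the effect of a longer chain on the amine nitrogen.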